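The compounds below may be only part of what the source reports. "The series", "measured", "known", "first", "only" and "open" are said of these compounds alone.

Of the compounds shown here, three sharing a common core have been tested for how strongly they harm cultured cells. In an ADME assay on HEp-2 cells (Homo sapiens) for cytotoxicity, read by MTT assay, with a stated time of 72 h (on this read-out lower numbers stand for stronger inhibition and higher numbers for weaker inhibition), compound 1 `COc1ccc(C2=C(c3cc(OC)c(OC)c(OC)c3)C(=O)CC2C)cc1C(=O)O` gives > 100 ug/mL, which is a limit of the assay and not a number. Compound 3 `COc1ccc(C2=C(c3cc(OC)c(OC)c(OC)c3)C(=O)C(O)C2)cc1Cl` gives < 1 ug/mL, and this too is a limit. Among the measured compounds shown here, compound 2 `COc1ccc(OC)c(C2=C(c3cc(OC)c(OC)c(OC)c3)C(=O)CC2O[SiH2]C(C)(C)C)c1` gives 19 ug/mL, the only true number among the three, so it is the one firm point for comparison.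

Compound 4 `COc1ccc(C2=C(c3cc(OC)c(OC)c(OC)c3)C(=O)CC2O[SiH2]C(C)(C)C)cc1OC` has the same atoms as compound 2, joined differently: 3,4-dimethoxyphenyl in place of 2,5-dimethoxyphenyl on a double-bonded ring carbon. Here 3,4-dimethoxyphenyl stands in place of 2,5-dimethoxyphenyl on a double-bonded ring carbon. For the measured compounds named here, no two measured compounds differ in only one place, so nothing measured shows how large such a swap might be in this assay. The expectation therefore starts from compound 2 at 19 ug/mL, and no step beyond the usual scatter is expected in either direction. The expected change is small: a 1.2-fold lower number from compound 2 to compound 4 (0.07 log units; within the scatter). The range is kept wide, as the measured compounds reach the limits at both ends of the assay. For compound 4 the estimated value is 16 ug/mL, with an expected range from 4 ug/mL to 60 ug/mL.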

Compound 4, half-maximal inhibitory concentration: > 100 ug/mL
Compound 4: a limit, no number; the forecaster's own chance of this, stated with the estimate: 10%; middle value at least 6.2-fold (0.79 log units) from the limit.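

In this assay, putting 3,4-dimethoxyphenyl in place of 2,5-dimethoxyphenyl on a double-bonded ring carbon gives an at least 5.2-fold higher number from compound 2 to compound 4 (0.72 log units; beyond the scatter), and this step lies beyond the usual scatter. This is the only pair shown that differs in one place, and since the two compounds have the same atoms, it shows that how the two methoxy groups are arranged on this phenyl ring can by itself shift the read-out, which the earlier compounds could not show. Compound 4 gives > 100 ug/mL, which is a limit of the assay and not a number, so the step gives only a smallest size and its full size cannot be read: the limit of > 100 ug/mL in this assay, at which 2 of the 4 values shown sit.

As far as these compounds go, it remains open whether a phenyl ring at this place carrying an amine or a nitrile instead of a methoxy group would give a number closer to that of compound 2 or to the limit of compound 4. From the compounds shown here alone, it is also open whether the same swap would give a step of similar size on a core that lacks the large group shared by compound 2 and compound 4.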